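Benzyl out, butylcarbamoyl in: a side-chain swap

The compounds below may be only part of what the source reports. "The series", "measured", "known", "first", "only" and "open" are said of these compounds alone.

Compound 1 `CC(C)(N)C(=O)N[C@H](COCc1ccccc1)c1nnnn1CCCc1ccccc1` gives 17 nM in a functional assay on H4 cells for agonist activity at growth hormone secretagogue receptor type 1 (Homo sapiens), read by FLIPR (on this read-out higher numbers stand for an effect only at larger amounts of compound and lower numbers for an effect already at smaller amounts), the lowest of the three measured numbers. Compound 2 `CC(C)(N)C(=O)N[C@H](COCc1ccccc1)c1nnn(Cc2cccc(NS(C)(=O)=O)c2)n1` gives 868 nM, and compound 3 `CC(C)(N)C(=O)N[C@H](COCc1ccccc1)c1nnn(CC#N)n1` gives 1520 nM; both lie well beyond the scatter from compound 1. For the measured compounds named here, the only step between measured neighbours, a 1.8-fold higher number from compound 2 to compound 3 (0.24 log units; within the scatter), compares two groups that both lack the chain of compound 1 and bears little on the change at hand. Compound 4 `CCCCNC(=O)CCn1nnnc1[C@@H](COCc1ccccc1)NC(=O)C(C)(C)N` differs from compound 1 by butylcarbamoyl in place of benzyl on a saturated chain carbon, two bonds along the chain from an aromatic nitrogen. Going by the values given here, no measured step covers this exact change, but both compounds that lack the benzyl-ended chain give far higher numbers than compound 1, so a weaker effect is expected. The estimated step is a 12-fold higher number from compound 1 to compound 4 (1.07 log units; beyond the scatter). Compound 4 is therefore expected to give about 200 nM, within 50 nM to 800 nM.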

Compound 4, half-maximal effective concentration: 42 nM
The estimate for compound 4 lay 4.8-fold (0.68 log units) above the measured number, outside the stated range (below it).
By their numbers in this assay, from the lowest: compound 1; then compound 4; then compounds 2 and 3 (each within the scatter of the next).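

In this assay butylcarbamoyl in place of benzyl gives a 2.5-fold higher number from compound 1 to compound 4 (0.39 log units; beyond the scatter) and so costs only a modest amount. A benzyl end with its aromatic ring is therefore not needed for a low number at this position, since a ringless group of the same heavy-atom count, carrying one hydrogen-bond donor and one acceptor, nearly keeps it. No evidence is available on why this swap is tolerated. Still open, on these data alone, is whether the carbonyl or the butyl part matters more, and how a carboxylic acid, an amine or a longer chain fares here.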